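This account rests on a few compounds, and the source may have more. Where it says the series, first, only, none or still open, it means among the compounds named here.

Three compounds have been measured so far, and each of them stops at a limit of the assay rather than giving a number:

Compound 1, `Cc1ccc(S(=O)(=O)N[C@@H](CC(=O)NC(C)(C)C)C(=O)NCCNC(=O)c2c(O)cccc2F)cc1`, gives in an ADME assay on Karpas-1106P cells (Homo sapiens) for cytotoxicity (a higher number here means that more compound is needed for the effect, a lower number that less compound is needed), a limit, > 11100 nM.
Compound 2, `Cc1ccc(S(=O)(=O)N[C@@H](CC(=O)NC(C)(C)C)C(=O)NCCNC(=O)c2ccccc2)cc1`, gives in this assay a limit, > 11100 nM.
Compound 3, `COc1cc(OC)cc(C(=O)NCCNC(=O)[C@H](CC(=O)NC(C)(C)C)NS(=O)(=O)c2ccc(C)cc2)c1`, gives in this assay a limit, > 11100 nM.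

Compound 3 therefore stands where the other two stand: at the limit described by the limit of > 11100 nM in this assay, at which 3 of the 3 values shown sit. The measured steps tell nothing about size or direction: a step that the two limits leave unreadable from compound 1 to compound 2, a step that the two limits leave unreadable from compound 1 to compound 3 and a step that the two limits leave unreadable from compound 2 to compound 3.

Compound 4, `Cc1ccc(S(=O)(=O)N[C@@H](CC(=O)NC(C)(C)C)C(=O)NCCNC(=O)c2ccc(F)cc2)cc1`, differs from compound 3 only at the group on the carbonyl carbon: 4-fluorophenyl in place of 3,5-dimethoxyphenyl on a carbonyl carbon. All three changes seen so far at this same carbonyl carbon left the readout at the limit, so no step beyond the scatter is expected here either, and the step from compound 3 to compound 4 is estimated as a step that the limit leaves unreadable from compound 3 to compound 4. Compound 4 is expected to give in this assay about 20000 nM, within 11100 nM to 60000 nM, most likely once more reported only as a limit.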

Compound 4, half-maximal effective concentration: > 11100 nM
Compound 4 gave a limit, no number; the forecaster's own chance of this, stated with the estimate: 90%; the middle value does not contradict the limit.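

In this assay compound 4 gives only a limit, > 11100 nM, so its steps from compound 1, compound 2 and compound 3 cannot be read, in size or in direction. The compounds shown leave open whether any group on this carbonyl carbon changes the read-out at all, because every value rests on one limit: the limit of > 11100 nM in this assay, at which 4 of the 4 values shown sit.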